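Trifluoromethyl for Methyl on the Benzyl Ring

The source may report more compounds than this note shows. Statements on the series, on what has been measured and on what is new or still open speak of the compounds shown alone.

Compound 3 `C/C(=C\C(=O)Nc1ccccc1OCCCC(=O)O)c1ccc2c(ccn2Cc2ccc(C)cc2)c1` gives 88 nM in an assay on Prostate gland for inhibition of steroid 5-alpha-reductase (Rattus norvegicus) (a lower number here means a stronger inhibitor, a higher number a weaker inhibitor), the highest of the three numbers recorded. Compound 1 `CCCCCn1ccc2cc(/C(C)=C/C(=O)Nc3ccccc3OCCCC(=O)O)ccc21` gives 23 nM and compound 2 `CCCCC(CCCC)n1ccc2cc(/C(C)=C/C(=O)Nc3ccccc3OCCCC(=O)O)ccc21` gives 21 nM in this assay . The step of a 1.1-fold lower number from compound 1 to compound 2 (0.04 log units; within the scatter), while the steps of a 3.8-fold higher number from compound 1 to compound 3 (0.58 log units; beyond the scatter) and a 4.2-fold higher number from compound 2 to compound 3 (0.62 log units; beyond the scatter) set compound 3 apart from both of the others. Compound 4 `C/C(=C\C(=O)Nc1ccccc1OCCCC(=O)O)c1ccc2c(ccn2Cc2ccc(C(F)(F)F)cc2)c1` differs from compound 3 by trifluoromethyl in place of methyl on an aromatic carbon. Going by the values given here, none of the measured steps touches this position: the two steps leading to compound 3 exchange the whole group on the aromatic nitrogen rather than a substituent on its outer ring, so they show only that this region of the molecule can shift the number modestly. Among the compounds with values here, there is no direct precedent for the present change. The expected step of a 1.1-fold higher number from compound 3 to compound 4 (0.06 log units; within the scatter) is therefore small, with no clear direction. The number for compound 4 is expected to be 100 nM, within a range from 40 nM to 250 nM.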

Compound 4, half-maximal inhibitory concentration: 300 nM
The estimate for compound 4 lay 3.0-fold (0.48 log units) below the measured number; measured number outside the range, above it.
By their numbers in this assay, from the lowest: compounds 2 and 1 (each within the scatter of the next); then compound 3; then compound 4.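

In this assay, the outer ring of the benzyl group proved able to shift the number by itself: with the rest of the molecule unchanged, trifluoromethyl in place of methyl gives a 3.4-fold higher number from compound 3 to compound 4 (0.53 log units; beyond the scatter). The earlier steps shown here had exchanged the whole group on the aromatic nitrogen, whereas this single substitution takes the series further from the compounds with saturated chains on that nitrogen, giving a 14-fold higher number from compound 2 to compound 4 (1.15 log units; beyond the scatter) and a 13-fold higher number from compound 1 to compound 4 (1.12 log units; beyond the scatter). No measurement at hand accounts for the step from methyl to trifluoromethyl.

With only these two groups shown at this carbon, it remains open whether hydrogen, fluorine, a methoxy group or a nitrile would fall nearer to compound 3 or to compound 4. As far as these compounds go, it also remains open whether trifluoromethyl would have a similar effect at another carbon of the ring.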